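This account rests on a few compounds, and the source may have more. Where it says the series, first, only, none or still open, it means among the compounds named here.

For the measured compounds named here, compound 3 `Cc1c(C(C)OC(=O)Nc2ccccc2)oc2nc(Cl)nn12` gives 10 nM in a functional assay on CHO cells for antagonist activity at metabotropic glutamate receptor 5 (Homo sapiens), read by calcium flux (on this read-out lower numbers stand for stronger inhibition and higher numbers for weaker inhibition), and stands lowest among the three compounds measured so far. Compound 1 `Cc1c(C(C)OC(=O)Nc2cccc(Cl)c2)oc2ncnn12` gives 39.8 nM in this assay; compound 2 `Cc1c(C(C)OC(=O)Nc2ccc(Cl)c(Cl)c2)oc2ncnn12` gives 5010 nM. Going by the values given here, the only single-point step within the measured set, a 130-fold higher number from compound 1 to compound 2 (2.10 log units; beyond the scatter), concerns the phenyl ring of the carbamate, where compound 2 carries a second chloro that compound 1 does not.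

Compound 4 `Cc1c(C(C)OC(=O)Nc2ccccc2)oc2nc(-c3cccs3)nn12` differs from compound 3 elsewhere: thiophen-2-yl in place of chloro on an aromatic carbon. Among the compounds with values here, no measured pair changes this position on the shared core, so the step from compound 1 to compound 2 does not bear on it, and the gap between compound 3 and compound 1 comes from two changes at once and cannot be split into parts. Within the data shown here, with no precedent in the set, the working assumption is that a group on this carbon is tolerated much as chloro is, and that the change moves this assay by no more than the scatter, with the direction open; a larger shift in either direction cannot be ruled out. Compound 4 is therefore expected to come in at 20 nM, within a range of 4 nM to 100 nM. The expected step, a 2.0-fold higher number from compound 3 to compound 4 (0.30 log units; within the scatter), is a small one.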

Compound 4, half-maximal inhibitory concentration: 7.94 nM
Compound 4: middle estimate off by 2.5-fold (0.40 log units), on the high side; the measured number falls inside the stated range.
By their numbers in this assay, from the lowest: compounds 4 and 3 (each within the scatter of the next); then compound 1; then compound 2.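

In this assay, a 1.3-fold lower number from compound 3 to compound 4 (0.10 log units; within the scatter) leaves thiophen-2-yl and chloro on this aromatic carbon of the five-membered aromatic ring with 3 nitrogen indistinguishable. The earlier compounds shown here gave no step at this position; this one shows that a single chlorine atom can give way to a five-membered aromatic ring of 5 heavy atoms, including 1 sulfur, without giving up the low number seen for compound 3. Nothing available here accounts for this result, so it stands as an observation only.

As far as these compounds go, whether the position accepts groups of a different kind stays open: an amine, a carboxylic acid or a longer alkyl chain on this carbon could behave quite differently, and a single aromatic ring does not speak for them. Also open, from the compounds shown here alone, is whether thiophen-2-yl on this carbon keeps the number low when the phenyl ring of the carbamate carries chloro, given that a 130-fold higher number from compound 1 to compound 2 (2.10 log units; beyond the scatter) shows how strongly substitution on that ring can move the read-out.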